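The compounds below may be only part of what the source reports. "The series", "measured", "known", "first", "only" and "open" are said of these compounds alone.

Measured compounds:
compound 1, `COc1cc(-c2cc(/C=C/C(=O)c3ccc(N)cc3)[nH]n2)cc(OC)c1OC`, 5100 nM
compound 2, `COc1ccc(-c2cc(/C=C/C(=O)c3cc(OC)c(OC)c(OC)c3)[nH]n2)cc1OC`, 3600 nM
compound 3, `COc1ccc(-c2cc(/C=C/C(=O)c3ccc(N)cc3)[nH]n2)cc1`, 4950 nM

In a functional assay on NCI-H460 cells (Homo sapiens) for inhibition, read by sulforhodamine B assay, with a stated time of 48 h (a lower number here means a stronger inhibitor of growth, a higher number a weaker inhibitor of growth), compound 1 gives the highest of the three numbers, yet compound 3 and compound 2 both lie within the usual scatter of it, so no order among them can be read. Compound 4, `COc1ccc(C(=O)/C=C/c2cc(-c3cc(OC)c(OC)c(OC)c3)n[nH]2)cc1`, is not yet measured. It differs from compound 1 in one place: methoxy in place of amino on an aromatic carbon. For the measured compounds named here, no pair of measured compounds shows this change, so nothing in the data sets its size or direction. Across the three measured compounds the numbers stay close together despite differing substituents, so only a small step, if any beyond the scatter, is expected. Compound 4 is therefore expected to give 5000 nM, with a range from 2500 nM to 10000 nM, a step of a 1.0-fold lower number from compound 1 to compound 4 (0.01 log units; within the scatter) that is expected to stay within the scatter.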

Compound 4, concentration for total growth inhibition: 3750 nM
Compound 4: the middle estimate sits 1.3-fold (0.12 log units) above what was measured, within the range that was stated.
By their numbers in this assay, from the lowest: compounds 2, 4, 3 and 1 (each within the scatter of the next).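

In this assay, methoxy in place of amino on the aromatic carbon para to a large group gives a 1.4-fold lower number from compound 1 to compound 4 (0.13 log units; within the scatter), so this change at this position has no readable effect. The hydrogen-bond donor that leaves with the amino group therefore brings no step beyond the scatter in this pair. No measured evidence bears on this result. As far as these compounds go, whether a carboxylic acid, a dimethylamino group or a longer alkoxy chain at this position would move the number beyond the scatter remains open.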